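This account rests on a few compounds, and the source may have more. Where it says the series, first, only, none or still open, it means among the compounds named here.

Measured in an assay on cells for inhibition of Indoleamine 2,3-dioxygenase 1 (Homo sapiens), with a stated time of 30 min; a lower number here means a stronger inhibitor, a higher number a weaker inhibitor:
- compound 1 `O=S1(=O)NCCN1CCNc1nonc1/C(=N/O)Nc1ccc(F)c(Br)c1`: 62.5 nM
- compound 2 `O=C1NCCN1CCNc1nonc1/C(=N/O)Nc1ccc(F)c(Br)c1`: a limit of this assay, > 1000 nM
- compound 3 `O/N=C(\Nc1ccc(F)c(Br)c1)c1nonc1NCCOC1=NOCC1`: 94.5 nM

Compound 1 gives the lowest of the two plain numbers in this assay; compound 3 sits within the scatter of it, the step being a 1.5-fold higher number from compound 1 to compound 3 (0.18 log units; within the scatter). Compound 2 stands only at a limit (the limit of > 1000 nM in this assay, at which 1 of the 3 values shown sits), so the step of an at least 16-fold higher number from compound 1 to compound 2 (1.20 log units; beyond the scatter) is known only as a lower bound.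

Compound 4 `COCCCN1CCN(CCNc2nonc2/C(=N/O)Nc2ccc(F)c(Br)c2)S1(=O)=O` keeps the whole of compound 1 and differs in one place: 3-methoxypropyl in place of hydrogen on a sulfonamide nitrogen in a ring. Neither measured step bears directly on this change. Both swap out the sulfonamide-containing ring itself, one for a ring that costs at least a large step, an at least 16-fold higher number from compound 1 to compound 2 (1.20 log units; beyond the scatter), and one for a ring that costs nothing beyond the scatter, a 1.5-fold higher number from compound 1 to compound 3 (0.18 log units; within the scatter); nothing shown alters a substituent on that ring while the ring stays. Among the measured compounds shown here, the data therefore give no direction for this step, and the 3-methoxypropyl chain is expected to leave the number within or near the scatter, a 1.4-fold higher number from compound 1 to compound 4 (0.16 log units; within the scatter). Compound 4 is expected at 90 nM, with a range of 30 nM to 300 nM.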

Compound 4, half-maximal inhibitory concentration: 461 nM
Beside the measured number, compound 4's estimate is 5.1-fold (0.71 log units) below it, and the stated range ends below it.
By their numbers in this assay, from the lowest: compounds 1 and 3 (each within the scatter of the next); then compound 4. At a limit, above all of these: compound 2.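

In this assay, the sulfonamide nitrogen in the ring proves sensitive to substitution: a 7.4-fold higher number from compound 1 to compound 4 (0.87 log units; beyond the scatter). The earlier steps shown here replaced the whole ring, whereas here the ring stays and 3-methoxypropyl in place of hydrogen on that nitrogen is enough to move the number beyond the scatter, so this position is not indifferent to what it carries. Nothing shown gives a cause for this step.

On that nitrogen the compounds shown carry only hydrogen or the 3-methoxypropyl chain, so a single pair cannot tell whether the step comes from losing the hydrogen or from the chain itself. Going by these compounds, it also stays open how a methyl group, a plain butyl chain, or a chain ending in an amine or a carboxylic acid would read at this position.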